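The source may hold more compounds than are shown below. What is called first, only, known or untested is meant among the compounds shown, and "the series" means these compounds.

Measured so far in an ADME assay on LLC-MK2 cells (Macaca mulatta) for cytotoxicity, read by spectrophotometry and crystal violet staining, with a stated time of 4 days; a higher number here means that more compound is tolerated, a lower number that less compound is tolerated:
Compound 1 `CC(C)n1ncc2c(C(=O)Nc3ccccn3)cc(-c3ccccc3)nc21` gives 12500 nM.
Compound 2 `CC(C)n1ncc2c(C(=O)N3CCc4cccnc43)cc(-c3cccs3)nc21` gives 50000 nM.
Compound 3 `CC(C)n1ncc2c(C(=O)Nc3cccc(S(=O)(=O)N(C)C)c3)cc(-c3cccs3)nc21` gives > 200000 nM, which is a limit of the assay rather than a number.

Of the two compounds with a plain number, compound 2 has the higher one, meaning more of it is tolerated by the cells; its nearest neighbour is compound 1, whose lower number lies beyond the usual scatter of repeated measurements. Compound 3 stands at the limit of > 200000 nM in this assay, at which 1 of the 3 values shown sits, so only a lower bound is known for it.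

The step under consideration leads from compound 2 to compound 4 `CC(C)n1ncc2c(C(=O)Nc3ccc(F)cc3F)cc(-c3cccs3)nc21`, which has not yet been measured. The change sits on the amide part of the molecule, while the shared core and the thiophene are kept:

a group of 9 heavy atoms (6 carbon, 1 nitrogen, 2 fluorine; one six-membered aromatic ring of carbon only) in place of a group of 9 heavy atoms (7 carbon, 2 nitrogen; one five-membered non-aromatic ring with 1 hetero atom, one six-membered aromatic ring with 1 hetero atom), on a carbonyl carbon

With the entering group a hydrogen-bond donor returns, as in compound 1 and compound 3. For the measured compounds named here, no pair of measured compounds differs in just one place, so no step of this kind can be read off directly. In this assay a modest step is expected, towards a somewhat lower number, a 1.7-fold lower number from compound 2 to compound 4 (0.22 log units; within the scatter), though the scatter could swallow it. Compound 4 is estimated at 30000 nM, within a range from 8000 nM to 150000 nM.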

Compound 4, half-maximal cytotoxic concentration: > 200000 nM
Compound 4: no number, only a limit; the forecaster's own chance of this, stated with the estimate: 15%; middle value at least 6.6-fold (0.82 log units) from the limit.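

In this assay, with the shared core and the thiophene kept, putting (2,4-difluorophenyl)amino on the carbonyl carbon in place of the earlier two-ring group gives an at least 4.0-fold higher number from compound 2 to compound 4 (0.60 log units; beyond the scatter), so this position alone can shift how much compound the cells tolerate. Going by these compounds, compound 4 gives > 200000 nM, which is a limit of the assay and not a number, so only the lower end of this step is fixed and its true size is unknown. Compound 3, which differs from compound 4 only in the amide part, sits at the same limit, so these two cannot be ranked against each other: the limit of > 200000 nM in this assay, at which 2 of the 4 values shown sit.

The change brings in a hydrogen-bond donor, removes the ring nitrogen and adds two fluorines all at once, so the compounds shown cannot say which of these matters. A plain phenylamino group on the same carbonyl carbon would separate the fluorines from the rest of the change, and a piperidine there would test whether an aromatic ring on the amide is needed at all.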